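The source may report more compounds than this note shows. Statements on the series, on what has been measured and on what is new or still open speak of the compounds shown alone.

Measured compounds and their readings:

Compound 1, `COc1cccc(N2CCN(C(=O)C(C)N3C(=O)CCC3=O)CC2)c1`: 0%
Compound 2, `COCC(C(=O)N1CCN(c2cccc(C(F)(F)F)c2)CC1)N1C(=O)CCC1=O`: 75%
Compound 3, `CC(C(=O)N1CCN(c2ccccc2)CC1)N1C(=O)CCC1=O`: 0%

In a functional assay on the whole organism (strain Swiss) with Mus musculus as the target, in the maximal electroshock model, with a stated time of 0.5 h, at a dose of 100 mg/kg by the intraperitoneal route (on this read-out lower numbers stand for a weaker effect and higher numbers for a stronger effect at the one dose given), compound 3 gives 0%, the same reading within the scatter as compound 1, and the two share the lowest number of the three. For the measured compounds named here, compound 2 sits far higher, but it differs from compound 3 in more than one place, so its value alone shows no single step. Going by the values given here, the one step that does change only one group, no change at the digits printed from compound 1 to compound 3 (within the scatter), left the reading unchanged.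

Compound 4, `CC(C(=O)N1CCN(c2ccc(Cl)cc2)CC1)N1C(=O)CCC1=O`, differs from compound 3 by chloro in place of hydrogen on an aromatic carbon. Among the compounds with values here, no measured step concerns this change, and the only single-group step known, no change at the digits printed from compound 1 to compound 3 (within the scatter), showed no movement at all. There is therefore no basis for expecting a step beyond the scatter in this assay, and compound 4 is estimated to move by a number 15 percentage points higher from compound 3 to compound 4 (beyond the scatter). Compound 4 is expected to give about 15%, within a range of 0% to 50%.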

Compound 4, a percentage reported as activity, at one dose (the size of the read-out at that dose, not a potency): 25%
Beside the measured number, compound 4's estimate is 10 percentage points below it, within the range that was stated.
By their numbers in this assay, from the lowest: compounds 1 and 3 (each within the scatter of the next); then compound 4; then compound 2.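

In this assay, for the compounds shown here, chloro in place of hydrogen, para to a large group on the six-membered aromatic ring, gives a number 25 percentage points higher from compound 3 to compound 4 (beyond the scatter) and is the first single change here to lift the reading beyond the scatter. The 4-chlorophenyl in place of 3-methoxyphenyl gives a number 25 percentage points higher from compound 1 to compound 4 (beyond the scatter), whereas hydrogen in place of methoxy gave no change at the digits printed from compound 1 to compound 3 (within the scatter), so this ring does respond to what it carries, though not to every change. Nothing measured here explains the rise.

Still open, on these data alone, is whether chloro is special at this place or whether another group, such as bromo, methyl or nitrile, would do the same. The compounds shown also leave open what chloro would do elsewhere on the ring.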